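The compounds below may be only part of what the source reports. "The series", "measured", "known", "first", "only" and "open" are said of these compounds alone.

Measured compounds:

- Compound 1 `C=CCc1ccc(OCc2cn(-c3ccccc3CO)nn2)c(O)c1`: 34.5%
- Compound 2 `C=CCc1cc(O)c(O)c(CN2CCC(CO)CC2)c1`: 26.2%
- Compound 3 `C#CCOc1ccc(CC=C)cc1O`: 23.7%

All three compounds were tested in a functional assay on MCF7 cells (Homo sapiens) for inhibition, read by MTT assay, with a stated time of 72 h, tested at 30 uM; a lower number here means less inhibition of growth, a higher number more inhibition of growth at the concentration tested. Compound 1 gives 34.5%, compound 2 gives 26.2% and compound 3 gives 23.7%. The three numbers sit close together: compound 2 differs from compound 3 and from compound 1 by amounts that fall within the usual scatter of repeated measurements, so none of the three can be called more or less active than another on these data alone.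

The step of interest runs from compound 2 to compound 4 `C=CCc1cc(O)c(O)c(CN2CCC(Cc3ccccc3)CC2)c1`, a compound that has not yet been measured in this assay. The two structures differ in one place: phenyl in place of hydroxy on a saturated chain carbon bound to a saturated ring carbon. The shared core of compound 2, with its two hydroxy groups on the aromatic ring and the saturated ring attached through a saturated chain carbon, is kept; only the end of the chain on the saturated ring changes.

Within the data shown here, no pair of measured compounds that differ in a single place is available, so the size of this kind of step is unknown here. With nothing to guide the direction, the step from compound 2 to compound 4 is expected to be a number 3.8 percentage points higher from compound 2 to compound 4 (within the scatter), a change not clearly beyond the scatter. Compound 4 is therefore estimated at 30%, with a plausible range from 12% to 50%.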

Compound 4, percent growth inhibition at one concentration: 70.9%
Estimate against measurement, compound 4: 40.9 percentage points below; the measured number lies above the stated range.
By their numbers in this assay, from the lowest: compounds 3, 2 and 1 (each within the scatter of the next, the first and the last beyond it); then compound 4.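

In this assay, among these compounds, putting phenyl in place of hydroxy on a saturated chain carbon bound to a saturated ring carbon, which can also be read as hydroxymethyl to benzyl, gives a number 44.7 percentage points higher from compound 2 to compound 4 (beyond the scatter) and is the only single-place step available here. It shows that this end of the molecule is not a neutral spot: with the shared core kept, one change here moves growth inhibition by a large step, well beyond the scatter of repeated measurements. The change removes one oxygen with its hydrogen-bond donor and acceptor and adds six carbons in an aromatic ring, but no measurement at hand explains why the number moves so far.

The compounds shown leave open whether the step depends on the aromatic ring itself or would also appear with a cyclohexylmethyl group or a plain hexyl chain in the same place, and whether a phenethyl group would keep it. They also leave open how a methoxy group or a fluorine on the new phenyl ring, or a simple amine at the end of the chain, would read in this assay.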